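Swapping an isopropyl for a pyridine on the amine

A few compounds are considered here, and "the series" means these few. Any claim that something is new, unique, unknown or untested is made for them only; others in the source may bear on it.

Measured compounds:
- compound 1 `Cc1csc2cc([C@H](C)Nc3ncnc(N)c3C#N)c(-c3cccc(CN4CCC(N(C)CC(C)C)CC4)c3)c(=O)n12`: 9.9 h
- compound 2 `Cc1csc2cc([C@H](C)Nc3ncnc(N)c3C#N)c(-c3cccc(CN4CCC(CN(C)CC(C)C)CC4)c3)c(=O)n12`: 12 h
- compound 3 `Cc1csc2cc([C@H](C)Nc3ncnc(N)c3C#N)c(Cc3cccc(CN4CCC4)c3)c(=O)n12`: 1.1 h

In an ADME assay on the whole organism (lung, Rattus norvegicus) for metabolic stability, read by LC-MS (a lower number here means that the compound disappears faster, a higher number that the compound lasts longer), compound 2 gives 12 h, the largest of the three numbers, although the gap to compound 1 at 9.9 h is within the scatter, so the two cannot be told apart. Compound 3 differs from compound 2 in several places. In this assay compound 3 gives 1.1 h, far lower than the number for compound 2.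

Compound 4 `Cc1csc2cc([C@H](C)Nc3ncnc(N)c3C#N)c(-c3cccc(CN4CCC(CN(C)Cc5ccccn5)CC4)c3)c(=O)n12` has not yet been measured. It differs from compound 2 by pyridin-2-yl in place of isopropyl on a saturated chain carbon bound to an amine nitrogen. Going by the values given here, the only measured step that touches this part of the molecule is a 1.2-fold higher number from compound 1 to compound 2 (0.08 log units; within the scatter), a change close to the same amine nitrogen that left the half-life essentially unchanged. Among the compounds with values here, no measured pair shows what replacing an alkyl group with a pyridine ring does here, so the evidence is thin.

On that basis compound 4 is expected to stay close to compound 2, with an estimated step of a 1.2-fold lower number from compound 2 to compound 4 (0.08 log units; within the scatter), none beyond the scatter. The estimate for compound 4 in this assay is 10 h, with a range from 5 h to 20 h.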

Compound 4, half-life: 10.9 h
Estimate against measurement, compound 4: 1.1-fold (0.04 log units) below, within the range that was stated.
By their numbers in this assay, from the lowest: compound 3; then compounds 1, 4 and 2 (each within the scatter of the next).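

In this assay, pyridin-2-yl in place of isopropyl on a saturated chain carbon bound to an amine nitrogen gives a 1.1-fold lower number from compound 2 to compound 4 (0.04 log units; within the scatter) and so shows no readable difference, even though an aromatic ring with a nitrogen atom now stands where a small branched alkyl group stood. The broader change, (methyl((pyridin-2-yl)methyl)amino)methyl in place of isobutyl(methyl)amino on a saturated ring carbon, gives a 1.1-fold higher number from compound 1 to compound 4 (0.04 log units; within the scatter) and likewise shows no readable difference, so compound 1, compound 2 and compound 4 cannot be told apart in this measurement. No measurement shown here offers an explanation for this result.

The compounds shown leave open whether this end of the molecule would tolerate a group of a different kind, such as a carboxylic acid or a primary amine, as it tolerates pyridin-2-yl and isopropyl. They also leave open which part of compound 3, at 1.1 h and different from compound 2 in several places, accounts for its far lower number.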